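Three Inactive Amides and a Chlorinated Analogue Ahead

The compounds below may be only part of what the source reports. "The series", "measured", "known", "first", "only" and "open" are said of these compounds alone.

compound 1, `O=C(/C=C/CCCCCCc1ccccc1)N[C@H]1CC[C@H](O)CC1`, gives in a functional assay on PANC-1 cells (Homo sapiens) for cytotoxicity, read by WST assay, with a stated time of 24 h (a lower number here means a stronger inhibitor, a higher number a weaker inhibitor), a limit of > 100000 nM.
compound 2, `S=C(CCCCCCCCc1ccccc1)N1CCCCC1`, gives in this assay a limit of > 100000 nM.
compound 3, `O=C(CCCCCCCCCc1ccccc1)N1CCCCC1`, gives in this assay a limit of > 100000 nM.

Every measured value here is a limit rather than a number, all three sitting at the limit of > 100000 nM in this assay, at which 3 of the 3 values shown sit. Going by the values given here, compound 3 therefore stands nowhere distinct among them, and no step between measured compounds can be read from these data. Compound 4, `O=C(CCCCCCCCc1cccc(Cl)c1)N1CCCCC1`, differs from compound 3 by 3-chlorophenyl in place of benzyl on a saturated chain carbon, eight bonds along the chain from a carbonyl carbon. Among the compounds with values here, with no measured step to lean on, the step that the limit leaves unreadable from compound 3 to compound 4 is expected to be none beyond the scatter in this assay. Compound 4 is accordingly estimated at about 150000 nM, within 50000 nM to 500000 nM, and most likely reported once more only as a limit.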

Compound 4, half-maximal inhibitory concentration: > 100000 nM
Compound 4: only a limit was reported (the forecaster's own chance of this, stated with the estimate: 80%); the middle value does not contradict the limit.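

In this assay compound 4 gives > 100000 nM, which is a limit. Going by these compounds alone, compound 3 gives > 100000 nM, also a limit, so no step from compound 3 to compound 4 can be read. The compounds shown leave open whether any of them differs from another in cytotoxicity: the limit of > 100000 nM in this assay, at which 4 of the 4 values shown sit.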